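This account rests on a few compounds, and the source may have more. Where it says the series, first, only, none or still open, it means among the compounds named here.

Measured so far:
- compound 1 `COc1cc(NC(=O)Nc2ccccn2)cc(-c2cccnc2)c1OC`: 22400 nM
- compound 2 `COc1cc(NC(=O)Nc2ccncc2)cc(-c2cccnc2)c1OC`: 73600 nM

Both values come from a functional assay on SMMC-7721 cells (Homo sapiens) for inhibition, read by MTT assay, with a stated time of 48 h (on this read-out higher numbers stand for weaker inhibition and lower numbers for stronger inhibition), and compound 1 has the lower number of the two, so it is the stronger inhibitor of this pair. For the measured compounds named here, the only measured step is a 3.3-fold higher number from compound 1 to compound 2 (0.52 log units; beyond the scatter). It is modest but beyond the scatter, and it replaces pyridin-2-yl with pyridin-4-yl on an amide-type nitrogen.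

Compound 3 `COc1cc(NC(=O)Nc2ccccn2)cc(-c2c[nH]cn2)c1OC` keeps the pyridin-2-yl of compound 1 and differs elsewhere: 1H-imidazol-4-yl in place of pyridin-3-yl on an aromatic carbon. This places 1H-imidazol-4-yl in place of pyridin-3-yl on an aromatic carbon. Going by the values given here, no measured step touches that place, so the step to compound 2 gives only a rough scale and no direction. In this assay, no change beyond the scatter is expected: a 1.3-fold higher number from compound 1 to compound 3 (0.10 log units; within the scatter). The estimate for compound 3 is 28000 nM, with an expected range of 8000 nM to 90000 nM.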

Compound 3, half-maximal inhibitory concentration: 21200 nM
Compound 3: middle estimate off by 1.3-fold (0.12 log units), on the high side; low and high end bracket the measured number.
By their numbers in this assay, from the lowest: compounds 3 and 1 (each within the scatter of the next); then compound 2.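

For the compounds shown here, at this place, ortho to a methoxy group on the carbon-only aromatic ring, 1H-imidazol-4-yl in place of pyridin-3-yl gives a 1.1-fold lower number from compound 1 to compound 3 (0.02 log units; within the scatter) in this assay, so this is the first measured change here and it cannot be told from the scatter. The entering group is a five-membered aromatic ring with 2 hetero atoms and 1 hydrogen-bond donor, so in this pair neither the ring size nor that donor goes with a change beyond the scatter. Nothing available bears on why the two groups read alike.

From the compounds shown here alone, whether an amine, a carboxylic acid or a plain phenyl ring at this place would also leave the number within the scatter stays open. Also open, going by these compounds, is whether 1H-imidazol-4-yl would behave the same alongside the pyridin-4-yl of compound 2.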